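Side-chain ring exchange on the shared core: compound 2 to 3

The source may report more compounds than this note shows. Statements on the series, on what has been measured and on what is new or still open speak of the compounds shown alone.

Measured so far:
compound 1: `CCO/C(O)=C1\C(COCCn2cc(N)n(C)c2=O)=NC(C)=C(C(=O)OC)C1c1ccccc1Cl`; in a functional assay (aorta) with Rattus norvegicus as the target (on this read-out higher numbers stand for weaker inhibition and lower numbers for stronger inhibition), compound 1 gives 25.1 nM
compound 2: `CCO/C(O)=C1\C(COCCN2CC(=O)NC2=O)=NC(C)=C(C(=O)OC)C1c1ccccc1Cl`; in this assay compound 2 gives 20 nM

Compound 2 holds the lowest of the two numbers in this assay, but its nearest neighbour, compound 1, sits within the scatter, so no order between the two is claimed. The unmeasured compound 3 `CCO/C(O)=C1\C(COCCN2CC(=O)N=C2N)=NC(C)=C(C(=O)OC)C1c1ccccc1Cl` differs from compound 2 by a group of 7 heavy atoms (3 carbon, 3 nitrogen, 1 oxygen; one five-membered non-aromatic ring with 2 hetero atoms) in place of a group of 7 heavy atoms (3 carbon, 2 nitrogen, 2 oxygen; one five-membered non-aromatic ring with 2 hetero atoms), on a saturated chain carbon, two bonds along the chain from an oxygen on a saturated carbon. Going by the values given here, the only measured step at this position, a 1.3-fold lower number from compound 1 to compound 2 (0.10 log units; within the scatter), exchanged the ring on the same chain carbon without moving the number beyond the scatter. The present exchange keeps the ring size and the count of hydrogen-bond donors, so for compound 3 no step beyond the scatter is expected in this assay, in either direction. For compound 3 the estimate is 22 nM, with a range from 8 nM to 60 nM. This estimate means an expected step of a 1.1-fold higher number from compound 2 to compound 3 (0.04 log units; within the scatter) for compound 3.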

Compound 3, half-maximal inhibitory concentration: 20 nM
Beside the measured number, compound 3's estimate is 1.1-fold (0.04 log units) above it; low and high end bracket the measured number.
By their numbers in this assay, from the lowest: compounds 2, 3 and 1 (each within the scatter of the next).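

Two more ring exchanges on the same saturated chain carbon stay within the scatter in this assay: no change at the digits printed from compound 2 to compound 3 (within the scatter) and a 1.3-fold lower number from compound 1 to compound 3 (0.10 log units; within the scatter). An exchange that keeps the heavy-atom count and replaces an oxygen with a nitrogen in the group therefore leaves the number unmoved, and all three pairs among compounds 1, 2 and 3 now read alike, whether the five-membered ring is aromatic or non-aromatic. No measurement shown accounts for this flat read-out.

As far as these compounds go, whether it extends to a group without a ring on this chain carbon, such as a primary amine or a carboxylic acid, stays open. The compounds shown also leave open how a six-membered ring such as morpholine, or a longer chain carrying the ring, would read.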